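The source may report more compounds than this note shows. Statements on the series, on what has been measured and on what is new or still open speak of the compounds shown alone.

Compound 1 `Brc1ccc(-c2csc(N/N=C/c3ccc(N4CCCC4)cc3)n2)cc1`. In an assay on isolated protein for inhibition of Amine oxidase [flavin-containing] B (Homo sapiens), read by fluorescence and Amplex Red, with a stated time of 30 min (on this read-out higher numbers stand for weaker inhibition and lower numbers for stronger inhibition), compound 1 gives > 1000000 nM, which is a limit of the assay and not a number.
Compound 2 `Clc1ccc(-c2csc(N/N=C/c3ccc(N4CCCC4)cc3)n2)cc1`. In this assay compound 2 gives 761000 nM.

Compound 1 thus stands at the assay limit in this assay, and only a limit is known for it; the bearing of this is the limit of > 1000000 nM in this assay, at which 1 of the 2 values shown sits. Going by the values given here, its one measured neighbour, chloro in place of bromo on an aromatic carbon, gives an at least 1.3-fold lower number from compound 1 to compound 2 (0.11 log units; that floor lies within the scatter), a step that does not rise out of the scatter.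

Compound 3 `Fc1ccc(-c2csc(N/N=C/c3ccc(N4CCCC4)cc3)n2)c(F)c1` carries the change (2,4-difluorophenyl in place of 4-bromophenyl on an aromatic carbon). Among the compounds with values here, the only measured step at this position, the exchange of one halogen for another on the same aromatic ring, stayed within the scatter, so no step beyond the scatter is expected in this assay in either direction. Compound 3 is therefore estimated at 1000000 nM, within 300000 nM to 3000000 nM. The step this estimate implies is a number no higher from compound 1 to compound 3 (the limit leaves the size open).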

Compound 3, half-maximal inhibitory concentration: 141000 nM
Compound 3: middle estimate off by 7.1-fold (0.85 log units), on the high side; the whole stated range lies above it.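

In this assay this position proves able to move the read-out beyond the scatter, which the exchange of one halogen for another did not show: 2,4-difluorophenyl in place of 4-chlorophenyl gives a 5.4-fold lower number from compound 2 to compound 3 (0.73 log units; beyond the scatter). Compound 3, at 141000 nM, is the most potent of the three shown, with steps beyond the scatter to both others, though the number remains large. 2,4-Difluorophenyl in place of 4-bromophenyl gives an at least 7.0-fold lower number from compound 1 to compound 3 (0.85 log units; beyond the scatter), and that size is only a floor: the limit of > 1000000 nM in this assay, at which 1 of the 3 values shown sits.

Open, going by these compounds, is whether the shift belongs to fluorine itself or to the presence of two halogens, as the change alters both at once. Also open, on these data alone, is how a phenyl ring carrying an amine or a carboxylic acid in place of halogen would read at this position.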